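A few compounds are considered here, and "the series" means these few. Any claim that something is new, unique, unknown or untested is made for them only; others in the source may bear on it.

Compound 1 `CC(C)c1cccc(C(C)C)c1NC(=O)NCC1(c2ccc(CC(C)(C)C)cc2)CCCC1` carries a 4-neopentylphenyl group on a saturated ring carbon of its five-membered ring. In an assay on microsomes for inhibition of acyl-CoA:cholesterol acyltransferase (Oryctolagus cuniculus) (a lower number here means a stronger inhibitor, a higher number a weaker inhibitor), compound 1 gives 159 nM, the highest number among the three measured compounds. Two other compounds differ from it only in that group. Compound 2 `COc1cccc(C2(CNC(=O)Nc3c(C(C)C)cccc3C(C)C)CCCC2)c1` gives 13 nM, and compound 3 `CC(C)c1cccc(C(C)C)c1NC(=O)NCC1(c2ccc(N)cc2)CCCC1` gives 29 nM. Both changes lower the number well beyond the scatter: a 12-fold lower number from compound 1 to compound 2 (1.09 log units; beyond the scatter), and a 5.5-fold lower number from compound 1 to compound 3 (0.74 log units; beyond the scatter). Between the two newer groups the gap is smaller, a 2.2-fold higher number from compound 2 to compound 3 (0.35 log units; beyond the scatter).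

The unmeasured compound 4 `CC(C)c1cccc(C(C)C)c1NC(=O)NCC1(c2cccc(N(C)C)c2)CCCC1` differs from compound 1 in one place: 3-(dimethylamino)phenyl in place of 4-neopentylphenyl on a saturated ring carbon. This change shares features with both measured steps. As with the 3-methoxyphenyl of compound 2, the entering 3-(dimethylamino)phenyl is a small group bringing one hydrogen-bond acceptor; as with the amino group of compound 3, the new substituent is nitrogen-based. Both of those steps brought the number down, one by a large and one by a modest amount, so a clearly lower number is expected here as well, near that of compound 2. Compound 4 is therefore expected to come out around 18 nM, with a likely range from 6 nM to 55 nM. That estimate amounts to an 8.8-fold lower number from compound 1 to compound 4 (0.95 log units; beyond the scatter).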

Compound 4, half-maximal inhibitory concentration: 33 nM
Estimate against measurement, compound 4: 1.8-fold (0.26 log units) below; measured number inside the range.
By their numbers in this assay, from the lowest: compound 2; then compounds 3 and 4 (each within the scatter of the next); then compound 1.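

In this assay there is a 4.8-fold lower number from compound 1 to compound 4 (0.68 log units; beyond the scatter), so a third group on this saturated ring carbon also gives a clearly lower number than the 4-neopentylphenyl group of compound 1. The nitrogen-bearing group does not match the methoxy group of compound 2, with dimethylamino in place of methoxy on an aromatic carbon giving a 2.5-fold higher number from compound 2 to compound 4 (0.40 log units; beyond the scatter), while the comparison with the 4-aminophenyl group gives a 1.1-fold higher number from compound 3 to compound 4 (0.06 log units; within the scatter) and so does not separate those two groups. No measurement available here accounts for these differences.

The compounds shown leave open how much the attachment point on the phenyl ring matters, since the step between compound 3 and compound 4 changes the substituent and its place together, and a 3-aminophenyl or 4-(dimethylamino)phenyl group on the same carbon would pull those two changes apart. An unsubstituted phenyl group there would also show how much of the drop from compound 1 comes with losing the neopentyl group and how much with the groups that replace it.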